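This account rests on a few compounds, and the source may have more. Where it says the series, first, only, none or still open, it means among the compounds named here.

Working notes on the series. Of the compounds shown here, three have numbers so far in a functional assay on cardiac atrium (Cavia porcellus); a higher number here means that more compound is needed for the effect, a lower number that less compound is needed. Compound 1 `CCOC(=O)C1=C(C)NC(C)=C(C(=O)OCC)C1c1c(C(F)(F)F)nc2sccn12` gives 1070 nM, the highest of the three. Compound 2 `COC(=O)C1=C(C)NC(C)=C(C(=O)OC)C1c1c(-c2ccccc2)nc2n1CCS2` is the nearest at 390 nM, and compound 3 `CCOC(=O)C1=C(C)NC(C)=C(C(=O)OCC)C1c1c(Cl)nc2sc(C)cn12` is the furthest at 31 nM. Both lie below compound 1 by more than the scatter. For the measured compounds named here, no two measured compounds differ in one place alone, so the set offers no clean step to carry over.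

Next in line is compound 4 `CCOC(=O)C1=C(C)NC(C)=C(C(=O)OCC)C1c1c(-c2ccc(Cl)c(Cl)c2Cl)nc2sccn12`, which keeps the core of compound 1 and changes a single group: 2,3,4-trichlorophenyl in place of trifluoromethyl on an aromatic carbon.

The closest guide is compound 2 at 390 nM, which also carries a six-membered aromatic ring of carbon only, although its core and esters differ from those of compound 1. On this thin evidence, a moderate step to a lower number is expected in this assay, and a step within the scatter cannot be ruled out. The estimated change runs a 3.1-fold lower number from compound 1 to compound 4 (0.49 log units; beyond the scatter). For compound 4 the expected value is 350 nM, with an estimated range of 70 nM to 1700 nM.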

Compound 4, half-maximal effective concentration: 430 nM
Beside the measured number, compound 4's estimate is 1.2-fold (0.09 log units) below it; the range from low to high includes it.
By their numbers in this assay, from the lowest: compound 3; then compounds 2 and 4 (each within the scatter of the next); then compound 1.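

For the compounds shown here, this position, on an aromatic carbon of a five-membered aromatic ring with 2 nitrogen, now has the first step that can be read at a single place: in this assay, 2,3,4-trichlorophenyl in place of trifluoromethyl gives a 2.5-fold lower number from compound 1 to compound 4 (0.40 log units; beyond the scatter) and the step is a modest one. On the core of compound 1, then, this carbon tolerates a change from a group of 4 heavy atoms with no ring to one of 9 heavy atoms with a six-membered aromatic ring of carbon only, and the number goes down rather than up. No measured property of these groups is available to account for the step.

This single pair cannot separate the contribution of the aromatic ring from that of its three chlorine atoms, and it gives no direction for the substitution pattern on that ring. Going by these compounds, how an amine or a carboxylic acid on this same carbon would behave in this assay remains open, as does whether the step carries over to any other core.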